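This account rests on a few compounds, and the source may have more. Where it says the series, first, only, none or still open, it means among the compounds named here.

Measured compounds:
compound 1 `COc1ccc(-c2cc(/C=C/C(=O)c3ccc(N)cc3)[nH]n2)cc1` with 9360 nM;
compound 2 `COc1cc(-c2cc(/C=C/C(=O)c3ccc(N)cc3)[nH]n2)cc(OC)c1OC` with 8660 nM;
compound 3 `COc1ccc(C(=O)/C=C/c2cc(-c3cc(OC)c(OC)c(OC)c3)n[nH]2)cc1OC` with 5370 nM.

These three numbers come from a functional assay on UACC-257 cells (Homo sapiens) for inhibition, read by sulforhodamine B assay, with a stated time of 48 h; a higher number here means that more compound is tolerated, a lower number that less compound is tolerated. Compound 2 sits within the usual scatter of both neighbours: compound 1 gives 9360 nM and compound 3 gives 5370 nM, and neither gap counts as a real difference. Going by the values given here, the one single-point step among the measured compounds, a 1.6-fold lower number from compound 2 to compound 3 (0.21 log units; within the scatter), swaps the group on the carbonyl carbon and stays within the scatter as well.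

Compound 4 `COc1ccc(-c2cc(/C=C/C(=O)c3ccc(N)cc3)[nH]n2)cc1OC` is not yet measured. It differs from compound 2 by one change: hydrogen in place of methoxy on an aromatic carbon. Among the compounds with values here, no measured step removes a methoxy group from this ring, so there is no direct precedent. What can be said is that compound 1 carries fewer methoxy groups on that ring than compound 2, and compound 1 gives 9360 nM, while compound 2 gives 8660 nM, two numbers within the scatter of each other. Taken with the small size of a 1.6-fold lower number from compound 2 to compound 3 (0.21 log units; within the scatter), the expectation is a step in this assay of no clear direction, a 1.0-fold higher number from compound 2 to compound 4 (0.02 log units; within the scatter). Compound 4 is therefore estimated at 9000 nM, within a range from 4000 nM to 20000 nM.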

Compound 4, concentration lethal to 50% of the cells: 45700 nM
Compound 4: middle estimate off by 5.1-fold (0.71 log units), on the low side; measured number outside the range, above it.
By their numbers in this assay, from the lowest: compounds 3, 2 and 1 (each within the scatter of the next); then compound 4.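

Going by these compounds alone, the two steps together show that the methoxy pattern on this ring matters in this assay, which the earlier compounds, all within the scatter of one another, gave no sign of: there is a 5.3-fold higher number from compound 2 to compound 4 (0.72 log units; beyond the scatter), and there is also a 4.9-fold higher number from compound 1 to compound 4 (0.69 log units; beyond the scatter). Compound 4 therefore stands apart from both of its one-change neighbours, and the number does not move in a single direction with the count of methoxy groups, since taking one away from compound 2 raises it and adding one to compound 1 raises it as well. No measurement at hand accounts for the rise in either step.

Going by these compounds, whether a fluorine, a hydroxyl or an ethoxy group on this aromatic carbon would behave like the hydrogen of compound 4 or like the methoxy of compound 2 stays open. Also open, on these data alone, is whether the same change would give a similar step with the 3,4-dimethoxyphenyl of compound 3 on the carbonyl carbon in place of 4-aminophenyl.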